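One Ring Stereocentre Inverted, Solubility Expected to Hold

The compounds below may be only part of what the source reports. "The series", "measured", "known", "first", "only" and "open" are said of these compounds alone.

In a physicochemical assay for solubility, in phosphate buffer (on this read-out higher numbers stand for higher solubility and lower numbers for lower solubility), compound 1 `C[C@H]1CN([C@@H](C)CO)C(=O)c2cccc(NC(=O)c3ccncc3)c2O[C@H]1CN(C)Cc1ccc(Oc2ccccc2)cc1` gives 93000 nM and so sits within the scatter of the other two measured compounds. Its mirror image, compound 2 `C[C@@H]1CN([C@H](C)CO)C(=O)c2cccc(NC(=O)c3ccncc3)c2O[C@@H]1CN(C)Cc1ccc(Oc2ccccc2)cc1`, gives 86000 nM and compound 3 `C[C@H]1CN([C@@H](C)CO)C(=O)c2cccc(NC(=O)c3ccncc3)c2O[C@@H]1CN(C)Cc1ccncc1` gives 100000 nM on the same read-out.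

Compound 4 `C[C@@H]1CN([C@@H](C)CO)C(=O)c2cccc(NC(=O)c3ccncc3)c2O[C@H]1CN(C)Cc1ccc(Oc2ccccc2)cc1` differs from compound 1 through the two compounds have the same atoms and bonds and differ only in configuration as drawn: 1 of 3 stereo elements differ; a stereocentre at a saturated ring carbon is drawn S in compound 1 and R in compound 4 and nothing leaves or enters; a stereocentre at a saturated ring carbon is drawn S in compound 1 and R in compound 4. Among the measured compounds shown here, the one measured step that bears on this is a 1.1-fold lower number from compound 1 to compound 2 (0.03 log units; within the scatter) even though every stereocentre is inverted there, and the fact that compounds 1 and 2 differ only in the configuration as drawn makes that pair the nearest comparison. Inverting a single centre is therefore expected to give no step in this assay beyond the scatter. The expected step is a 1.0-fold lower number from compound 1 to compound 4 (0.01 log units; within the scatter) and it should stay small. For compound 4 the estimate is 90000 nM with an expected range from 55000 nM to 145000 nM on this read-out.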

Compound 4, solubility: 1000 nM
Compound 4: middle estimate off by 90-fold (1.95 log units), on the high side; measured number below the stated range.
By their numbers in this assay, from the lowest: compound 4; then compounds 2, 1 and 3 (each within the scatter of the next).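

A single stereocentre at a saturated ring carbon can matter a great deal in this assay, even though inverting all three centres together had left the number within the scatter: this one inversion gives a 93-fold lower number from compound 1 to compound 4 (1.97 log units; beyond the scatter). Nothing leaves or enters in this step, so the large change can be traced only to the arrangement in space, because the atoms and bonds stay the same: the fact that compounds 1 and 4 differ only in the configuration as drawn. Compound 4 also stands well apart from the mirror image of compound 1, with an 86-fold lower number from compound 2 to compound 4 (1.93 log units; beyond the scatter), so among these compounds the way the centres are arranged relative to one another counts, and the mirror-image pair could not reveal this.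

Going by these compounds, it remains open whether inverting the stereocentre at the saturated chain carbon alone would give a step of this kind. Also open, on these data alone, is whether a carboxylic acid added to the shared core would keep the number high in the configuration of compound 4.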